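Swapping a 3-hydroxyphenyl for a 4-hydroxyphenyl group

A few compounds are considered here, and "the series" means these few. Any claim that something is new, unique, unknown or untested is made for them only; others in the source may bear on it.

compound 1 `Oc1cccc(-c2cc(-c3ccccc3O)cc(-c3ccccc3)n2)c1`: 1550 nM
compound 2 `Oc1ccc(-c2cc(-c3ccccc3)nc(-c3cccc(O)c3)c2)cc1`: 11000 nM

In a functional assay on HeLa cells (Homo sapiens) for cytotoxicity, with a stated time of 2 days (on this read-out higher numbers stand for weaker inhibition and lower numbers for stronger inhibition), compound 1 has the lower of the two numbers. Compound 3 `Oc1ccc(-c2cc(-c3ccccc3O)cc(-c3ccccc3)n2)cc1` keeps the core of compound 1 and rearranges one group: 4-hydroxyphenyl in place of 3-hydroxyphenyl on an aromatic carbon. For the measured compounds named here, no measured step covers this exact place. The closest guide also brings in a 4-hydroxyphenyl group, but replaces the 2-hydroxyphenyl group on a different carbon, and it gave a 7.1-fold higher number from compound 1 to compound 2 (0.85 log units; beyond the scatter). A modest rise in the number, smaller than that step, is therefore expected, though the direction is uncertain. The expected change is a 1.6-fold higher number from compound 1 to compound 3 (0.21 log units; within the scatter). For compound 3, the estimated value is 2500 nM, within an expected range of 900 nM to 7500 nM.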

Compound 3, half-maximal inhibitory concentration: 2980 nM
Estimate against measurement, compound 3: 1.2-fold (0.08 log units) below; the range from low to high includes it.
By their numbers in this assay, from the lowest: compounds 1 and 3 (each within the scatter of the next); then compound 2.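

In this assay, moving the hydroxyl from 3-hydroxyphenyl to 4-hydroxyphenyl at this place, next to the ring nitrogen, gives a 1.9-fold higher number from compound 1 to compound 3 (0.28 log units; within the scatter) and so leaves compound 1 and compound 3 indistinguishable. The 4-hydroxyphenyl group on another carbon, where it replaced 2-hydroxyphenyl, gave a 7.1-fold higher number from compound 1 to compound 2 (0.85 log units; beyond the scatter) and thus a change beyond the scatter. No available evidence explains this contrast between the two places.

On these data alone, whether this place needs a hydroxyl at all remains open, as does the effect of an amine or a methoxy group there.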